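The source may report more compounds than this note shows. Statements on the series, on what has been measured and on what is new or still open speak of the compounds shown alone.

Three analogues sharing one core have been examined in a functional assay on C6 cells (Rattus norvegicus) for cytotoxicity, read by MTT assay, with a stated time of 24 h, tested at 25 ug/mL; on this read-out higher numbers stand for a weaker effect at the one concentration tested and lower numbers for a stronger effect. Compound 1 `Cc1ccc(-c2cs/c(=N/NC(=O)CSc3nnnn3-c3ccccc3)n2-c2ccccc2)cc1` gives 38.8%, compound 2 `Cn1nnnc1SCC(=O)N/N=c1/scc(-c2ccccc2)n1-c1ccccc1` gives 64.2%, and compound 3 `O=C(CSc1ncccn1)N/N=c1/scc(-c2ccc(Br)cc2)n1-c1ccccc1` gives 72.3%. Compound 3 thus holds the highest number of the three, although compound 2 lies within the scatter of it, while compound 1 sits beyond the scatter at a lower number. The step to compound 4 `Cc1ccc(-c2cs/c(=N/NC(=O)CSc3ncccn3)n2-c2ccccc2)cc1` is a single change: methyl in place of bromo on an aromatic carbon. Among the compounds with values here, no measured pair isolates this change, so the expectation rests on compound 3 alone. A step no larger than the scatter is expected in this assay, in either direction. On that basis compound 4 is estimated at 66%, ranging from 46% to 86%, a step of a number 6.3 percentage points lower from compound 3 to compound 4 (within the scatter).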

Compound 4, a percentage reported as activity, at one concentration (the size of the read-out at that concentration, not a potency): 82.7%
Estimate against measurement, compound 4: 16.7 percentage points below, and the stated range covers the measured number.
By their numbers in this assay, from the lowest: compound 1; then compounds 2 and 3 (each within the scatter of the next); then compound 4.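

In this assay, the change from 4-bromophenyl to 4-methylphenyl can now be read on its own: it gives a number 10.4 percentage points higher from compound 3 to compound 4 (beyond the scatter), a modestly weaker effect at the one concentration tested. With the methyl held in place, pyrimidin-2-yl in place of 1-phenyl-1H-tetrazol-5-yl on the sulfur gives a number 43.9 percentage points higher from compound 1 to compound 4 (beyond the scatter), so the change at the sulfur has the larger effect. No measured evidence bears on the cause of either step. On these data alone, whether a chloro, methoxy or amino group on this ring would behave like methyl or bromo stays open. So does whether the change at the sulfur holds with bromo in place of methyl.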